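The compounds below may be only part of what the source reports. "The series", "measured", "known", "first", "only" and "open" are said of these compounds alone.

Measured in a functional assay on DU-145 cells (Homo sapiens) for cytotoxicity, read by MTT assay, with a stated time of 48 h; a lower number here means a stronger inhibitor, a higher number a weaker inhibitor:
- Compound 1 `COc1ccc(/C=C/c2cc(OC)c(OC)c(OC)c2-c2ccc(F)c(F)c2)cc1`: 7500 nM
- Compound 2 `COc1cc(/C=C/c2ccc(C)cc2)c(-c2ccccc2)c(OC)c1OC`: 101000 nM
- Compound 3 `C=C(c1ccc(OC)cc1)c1cc(OC)c(OC)c(OC)c1-c1ccc(F)c(F)c1`: 6800 nM

Compound 3 at 6800 nM and compound 1 at 7500 nM lie within the scatter of each other, while compound 2 gives a clearly higher number at 101000 nM.

The next change leads to compound 4 `C=C(c1ccc(OC)cc1)c1cc(OC)c(OC)c(OC)c1-c1ccc2ccccc2c1`: naphthalen-2-yl in place of 3,4-difluorophenyl on an aromatic carbon.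

Among the measured compounds shown here, the one measured step, a 1.1-fold lower number from compound 1 to compound 3 (0.04 log units; within the scatter), concerns the 1-(4-methoxyphenyl)ethenyl and 2-(4-methoxyphenyl)ethenyl groups, not the group exchanged here. It therefore gives no size for this change. For the measured compounds named here, compound 2, at 101000 nM, is the only measured compound without the 3,4-difluorophenyl group. It also differs from compound 1 in another place, so its value cannot be assigned to either difference alone. Going by the values given here, it still gives a weak hint that the group at this position may matter, and no measured compound carries naphthalen-2-yl.

In this assay, a modest move towards a higher number is therefore expected, with wide uncertainty. The expected step is a 2.2-fold higher number from compound 3 to compound 4 (0.34 log units; beyond the scatter).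

For compound 4 the estimate is 15000 nM, with an expected range of 4000 nM to 55000 nM.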

Compound 4, half-maximal inhibitory concentration: 46000 nM
Compound 4: middle estimate off by 3.1-fold (0.49 log units), on the low side, within the range that was stated.
By their numbers in this assay, from the lowest: compounds 3 and 1 (each within the scatter of the next); then compound 4; then compound 2.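

In this assay, among the compounds shown here, exchanging 3,4-difluorophenyl for naphthalen-2-yl on the aromatic carbon ortho to the 1-(4-methoxyphenyl)ethenyl group gives a 6.8-fold higher number from compound 3 to compound 4 (0.83 log units; beyond the scatter), the first single-place change to lie beyond the scatter. The group on this carbon therefore bears on the read-out, unlike the ethenyl attachment change examined earlier, and with the remainder of the structure held constant, the higher number goes with the two-ring group in this single pair. No measurement bears on the reason for this step, so it remains an observation without an assigned cause.

A single exchange removes both fluorines and adds a second aromatic ring, so the compounds shown leave open which of these two differences accounts for the step, and whether it would carry over to the 2-(4-methoxyphenyl)ethenyl series. Also open, going by these compounds, is how this position would respond to a 4-fluorophenyl group, which keeps a single ring, or to a 3-aminophenyl or pyridin-3-yl group, which brings nitrogen to the same carbon.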